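Three compounds level, a fourth awaited

The source may report more compounds than this note shows. Statements on the series, on what has been measured and on what is new or still open speak of the compounds shown alone.

Measured compounds, all in a functional assay on DU-145 cells (Homo sapiens) for inhibition, read by trypan blue exclusion, with a stated time of 96 h; on this read-out lower numbers stand for stronger inhibition of growth and higher numbers for weaker inhibition of growth:
compound 1 `O=C(/C(=C\c1ccc(Br)c(O)c1)Sc1ccc(Br)cc1)c1ccc(Br)cc1`: 1000 nM
compound 2 `COc1ccc(S/C(=C/c2ccc(Cl)cc2Cl)C(=O)c2ccc(Br)cc2)cc1`: 1000 nM
compound 3 `O=C(/C(=C\c1ccc(Br)c([N+](=O)[O-])c1)Sc1ccc(Br)cc1)c1ccc(Br)cc1`: 1000 nM

On these numbers compound 1 has no edge and no deficit. Compound 1 gives 1000 nM, and its two neighbours read the same, with compound 2 at 1000 nM and compound 3 at 1000 nM.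

The next compound, compound 4 `O=C(/C(=C\c1ccc(F)cc1Cl)Sc1ccc(Br)cc1)c1ccc(Br)cc1`, has not yet been measured. It departs from compound 1 in a single place: 2-chloro-4-fluorophenyl in place of 4-bromo-3-hydroxyphenyl on a double-bonded chain carbon bound to a double-bonded chain carbon. The hydroxy group is therefore gone, and the halogens on that aromatic group are different.

Going by the values given here, one measured step bears on this change. Replacing hydroxy with nitro on an aromatic carbon of the same group gave no change at the digits printed from compound 1 to compound 3 (within the scatter). Among the compounds with values here, that step shows the hydroxy group can be replaced without a visible shift in the value, although no measured step isolates a change of halogens. Three equal values also give no trend to extrapolate, so no step beyond the scatter is expected in this assay.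

The expected outcome is no change at the digits printed from compound 1 to compound 4 (within the scatter). For compound 4 the estimated value is 1000 nM, with an expected range from 400 nM to 2500 nM.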

Compound 4, concentration for 50% growth inhibition: 1000 nM
For compound 4 middle estimate and measured number coincide at the digits printed, and the stated range covers the measured number.
By their numbers in this assay, from the lowest: compounds 1, 2, 3 and 4 (each within the scatter of the next).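

In this assay, the entire aromatic group on a double-bonded chain carbon bound to a double-bonded chain carbon was exchanged, and the outcome was no change at the digits printed from compound 1 to compound 4 (within the scatter). Going by these compounds alone, the earlier step to compound 3 had replaced only the hydroxy group, whereas here the hydroxy group and the bromine leave together, and the entering 2-chloro-4-fluorophenyl counts 0 hydrogen-bond donors and 0 hydrogen-bond acceptors, so this place tolerates a wider change than the earlier compounds showed, with a different halogen pair and no hydroxy or nitro group on the ring. No supporting measurement is available to explain why the value holds across this exchange.

The compounds shown leave open whether this level value would persist with a group of another kind at this place, such as a carboxylic acid, a dimethylamino group or a cyclohexyl ring in place of the aromatic group. They also do not separate the contribution of the chlorine from that of the fluorine, since both enter in the same step, and they give no view of changes to the two 4-bromophenyl parts of the core of compound 1.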